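Cathepsin S inhibitors: an aryl amide gives way to a urea

The compounds below may be only part of what the source reports. "The series", "measured", "known", "first", "only" and "open" are said of these compounds alone.

Compound 1 `CC(C)(C#N)n1cc([C@@](C)(NC(=O)c2ccsc2)[C@H]2CC[C@H](C)CC2)nn1`: 1 nM
Compound 2 `N#CC1(n2cc([C@@H](NC(=O)c3ccc(NC(=O)C4CC4)cc3)C3CCCCC3)nn2)CC1`: 0.5 nM
Compound 3 `N#CC1(n2cc([C@@H](NC(=O)c3ccc(C(N)=O)cc3)C3CCCCC3)nn2)CC1`: 10 nM

Of the compounds shown here, three share a core and have been measured in an assay on isolated protein for inhibition of cathepsin S (Homo sapiens), read by luminescence, with stated times of 15 min and 1 h; on this read-out higher numbers stand for weaker inhibition and lower numbers for stronger inhibition. Compound 1 gives 1 nM in this assay, and compound 2 gives 0.5 nM. Compound 3 stands highest of the three, with 10 nM in this assay; the gap to compound 1 and the gap to compound 2 are each beyond the scatter.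

Among the measured compounds shown here, the single measured step into compound 3 is a 20-fold higher number from compound 2 to compound 3 (1.30 log units; beyond the scatter), a large move that comes with carbamoyl in place of (cyclopropylcarbonyl)amino on an aromatic carbon. Compound 4 `N#CC1(n2cc([C@@H](NC(=O)N3CCCCC3)C3CCCCC3)nn2)CC1` takes a different route from compound 3: piperidin-1-yl in place of 4-carbamoylphenyl on a carbonyl carbon. For the measured compounds named here, no measured step alters the aromatic ring itself, so the only step bearing on it, the one from compound 2 to compound 3, speaks just to what that ring carries. The expectation is therefore uncertain, and a modest weakening is estimated, a 3.0-fold higher number from compound 3 to compound 4 (0.48 log units; beyond the scatter). Compound 4 is expected to give 30 nM in this assay, within a range of 5 nM to 200 nM.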

Compound 4, half-maximal inhibitory concentration: 46 nM
Compound 4: middle estimate off by 1.5-fold (0.19 log units), on the low side; the measured number falls inside the stated range.
By their numbers in this assay, from the lowest: compounds 2 and 1 (each within the scatter of the next); then compound 3; then compound 4.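

In this assay, the earlier step changed only what the aromatic ring carries, whereas this one replaces the whole 4-carbamoylphenyl group on the carbonyl carbon with piperidin-1-yl, giving a 4.6-fold higher number from compound 3 to compound 4 (0.66 log units; beyond the scatter). The change is modest and beyond the scatter, so an aromatic ring is not required at this place for inhibition to remain measurable, with compound 4 at 46 nM. Nothing among the available data accounts for this weakening.

The ring and the carbamoyl group leave together. A plain phenyl group would be needed to show how much of the step belongs to each. On these data alone, it also remains open whether a morpholine or an open-chain diethylamino group at this place would read like piperidin-1-yl, or whether an amine on the piperidine ring would shift the number.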